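Swapping Isopropyl for 4-Fluorophenyl: Expected Solubility

The source may report more compounds than this note shows. Statements on the series, on what has been measured and on what is new or still open speak of the compounds shown alone.

Compound 1 `CC(C)Cc1ccc2c(NCCCNCc3ccco3)ccnc2c1` was tested in a physicochemical assay for solubility, with a stated time of 18 h, at pH 7.4 (a lower number here means a less soluble compound, a higher number a more soluble compound), and gives 4200 nM. Compound 2 `COc1ccc(F)cc1CNCCCNc1ccnc2cc(CC(C)C)ccc12` gives 4200 nM, and compound 3 `COc1cccc(Oc2ccc3c(NCCCNCc4cccc(OC)c4O)ccnc3c2)c1` gives 14500 nM. Compound 1 thus sits level with compound 2, and together they give the lowest of the three numbers, with compound 3 the furthest away. Within the data shown here, the only measured step, no change at the digits printed from compound 1 to compound 2 (within the scatter), alters a group on a saturated chain carbon bound to an amine nitrogen. Compound 4 `Fc1ccc(Cc2ccc3c(NCCCNCc4ccco4)ccnc3c2)cc1` differs from compound 1 elsewhere: 4-fluorophenyl in place of isopropyl on a saturated chain carbon bound to an aromatic carbon. Among the measured compounds shown here, no measured step carries this change, so the one available step is only an indirect guide. Compound 4 is expected to give 2500 nM, between 800 nM and 8000 nM. The expected step of a 1.7-fold lower number from compound 1 to compound 4 (0.23 log units; within the scatter) is therefore modest, leaning downward, and close to the scatter.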

Compound 4, solubility: 4200 nM
For compound 4 the middle estimate is 1.7-fold (0.23 log units) below the measured one, and the stated range covers the measured number.
By their numbers in this assay, from the lowest: compounds 1, 2 and 4 (each within the scatter of the next); then compound 3.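

Placing 4-fluorophenyl in place of isopropyl on a saturated chain carbon bound to an aromatic carbon gives no change at the digits printed from compound 1 to compound 4 (within the scatter) in this assay. Among these compounds, the only earlier step changed a group elsewhere, so this is the first reading at this position, and here a larger, ring-bearing group leaves the number within the scatter. Nothing available explains this outcome.

Going by these compounds, whether an amine or a carboxylic acid at this position would also leave the number in place remains open. So does the result of combining this change with the 5-fluoro-2-methoxyphenyl change in one compound.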